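Anilide extension on the shared core: expected tolerability

The compounds below may be only part of what the source reports. "The series", "measured", "known", "first", "only" and "open" are said of these compounds alone.

Compound 3 `Cn1c(-c2ccc(N)cc2)nc2cc(C(F)(F)F)ccc21` gives 20000 nM in an ADME assay on MT4 cells (Homo sapiens) for cytotoxicity, read by MTT assay, with a stated time of 96 h (a lower number here means that less compound is tolerated, a higher number that more compound is tolerated), the higher of the two numbers recorded; compound 2 `CC(=O)Nc1ccc(-c2nc3cc(C(F)(F)F)ccc3n2C)cc1` gives 15000 nM, and the step of a 1.3-fold higher number from compound 2 to compound 3 (0.12 log units; within the scatter) separates them. Compound 1 `Cn1c(-c2ccc([N+](=O)[O-])cc2)nc2cc(C(F)(F)F)ccc21` sits at a limit of this assay, >= 100000 nM. From that limit the steps of an at least 6.6-fold lower number from compound 1 to compound 2 (0.82 log units; beyond the scatter) and an at least 5.0-fold lower number from compound 1 to compound 3 (0.69 log units; beyond the scatter) are both at least modest. Compound 4 `Cn1c(-c2ccc(NC(=O)CN3CCCCC3)cc2)nc2cc(C(F)(F)F)ccc21` carries ((piperidin-1-yl)methyl)carbonyl in place of hydrogen on a nitrogen on an aromatic ring. Within the data shown here, the step that bears on it is the one between compound 2 and compound 3, an acyl against a hydrogen on the same nitrogen, which stayed within the scatter; the larger group here is not covered by any measurement. The expected step is therefore a 1.7-fold lower number from compound 3 to compound 4 (0.22 log units; within the scatter), and compound 4 is estimated at 12000 nM, within 4000 nM to 40000 nM.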

Compound 4, half-maximal cytotoxic concentration: 9000 nM
Estimate against measurement, compound 4: 1.3-fold (0.12 log units) above; measured number inside the range.
By their numbers in this assay, from the lowest: compounds 4, 2 and 3 (each within the scatter of the next, the first and the last beyond it). At a limit, above all of these: compound 1.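

In this assay, ((piperidin-1-yl)methyl)carbonyl on the aromatic amine nitrogen gives a modest step beyond the scatter, a 2.2-fold lower number from compound 3 to compound 4 (0.35 log units; beyond the scatter), which the acetyl group did not give. Piperidin-1-yl on the saturated chain carbon bound to the carbonyl carbon stays within the scatter, a 1.7-fold lower number from compound 2 to compound 4 (0.22 log units; within the scatter), so the ring adds no readable change over the acetamide. The value of compound 1 is a limit, so the large step to the piperidine amide is only a bound, an at least 11-fold lower number from compound 1 to compound 4 (1.04 log units; beyond the scatter): the limit of >= 100000 nM in this assay, at which 1 of the 4 values shown sits.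

On these data alone, whether morpholine, a dimethylamino group or a longer chain in place of piperidin-1-yl would read the same stays open.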